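The source may report more compounds than this note shows. Statements on the series, on what has been measured and on what is new or still open speak of the compounds shown alone.

Compound 1 `Cc1ncnc2c1c(I)cn2[C@@H]1O[C@H](CO)[C@@H](O)[C@H]1O` carries an iodo group on the five-membered ring of its core. In a functional assay on HCT-116 cells (Homo sapiens), read by MTT assay, with a stated time of 72 h (a lower number here means a stronger inhibitor, a higher number a weaker inhibitor), compound 1 gives 4720 nM. Compound 2 `C#Cc1cn([C@@H]2O[C@H](CO)[C@@H](O)[C@H]2O)c2ncnc(C)c12` shares that core but bears an ethynyl group in the same place. In this assay compound 2 reaches only the limit of > 20000 nM, so no number is known for it. The change from compound 2 to compound 1 is iodo in place of ethynyl on an aromatic carbon, and it brought an at least 4.2-fold lower number from compound 2 to compound 1 (0.62 log units; beyond the scatter).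

Compound 3 `C#Cc1cn([C@@H]2O[C@H](CO)[C@@H](O)[C@H]2O)c2nc(C)nc(N)c12` also carries an ethynyl group, on a different core; how the two cores differ is not broken down here. In this assay compound 3 likewise sits at the limit of > 20000 nM, which is a limit and not a number. Compound 4 `Cc1nc(N)c2c(I)cn([C@@H]3O[C@H](CO)[C@@H](O)[C@H]3O)c2n1` is the iodo counterpart of compound 3, and the change from compound 3 to compound 4 is iodo in place of ethynyl on an aromatic carbon, the same change as that from compound 2 to compound 1.

The step is expected to be an at least 3.3-fold lower number from compound 3 to compound 4 (0.52 log units; beyond the scatter), resting on compound 1 with 4720 nM and on (the limit of > 20000 nM in this assay, at which 2 of the 3 values shown sit). Compound 4 is therefore estimated at 6000 nM, likely between 2000 nM and 20000 nM.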

Compound 4, half-maximal inhibitory concentration: > 20000 nM
Compound 4: no number, only a limit (the forecaster's own chance of this, stated with the estimate: 30%); middle value at least 3.3-fold (0.52 log units) away from the limit.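

In this assay compound 3 and compound 4 both stand at a limit and not at a number, so no step can be read between them: the limit of > 20000 nM in this assay, at which 3 of the 4 values shown sit.

The compounds shown leave open whether iodo in place of ethynyl lowers the number on the core of compound 3 as it does on the core of compound 1.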